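The compounds below may be only part of what the source reports. "The series", "measured", "known", "first", "only" and "open" are said of these compounds alone.

Compound 1 `CCNc1cc(-c2ccc(NC(=O)Nc3ccc(C)cc3)cc2C)ccn1` and compound 2 `CCNc1cc(-c2ccc(NC(=O)Nc3ccc(C(F)(F)F)cc3)cc2C)ccn1` share a core and differ only in the group on the terminal phenyl of the urea. In an assay on isolated protein for inhibition of serine/threonine-protein kinase PLK1 (Homo sapiens), read by radiometric assay and 33P incorporation, with a stated time of 40 min, tested at 20 uM, in the presence of a further agent that is not named here (on this read-out higher numbers stand for more inhibition at the one concentration tested (going by the name of the read-out) and lower numbers for less inhibition), compound 1 gives 47.5%, and compound 2 gives 54.8%. For the measured compounds named here, the single step recorded, a number 7.3 percentage points higher from compound 1 to compound 2 (within the scatter), is within the scatter, so on these two numbers compound 2 and compound 1 cannot be told apart.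

Compound 3 `CCNc1cc(-c2ccc(NC(=O)Nc3c(C)cccc3C)cc2C)ccn1` carries the change (2,6-dimethylphenyl in place of 4-(trifluoromethyl)phenyl on an amide-type nitrogen). Going by the values given here, no measured step covers this kind of change: the one recorded step swapped one group for another at the same place on that phenyl, and nothing shows what moving to a 2,6-dimethylphenyl does. The expectation for compound 3 therefore rests on compound 2 alone, and the step is estimated as a number 12.8 percentage points lower from compound 2 to compound 3 (beyond the scatter), with wide uncertainty. Compound 3 is expected to give 42%, in a range from 15% to 68%.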

Compound 3, a percentage reported as inhibition, at one concentration (the size of the read-out at that concentration, not a potency): 42.1%
Compound 3: middle estimate off by 0.1 percentage points, on the low side; the measured number falls inside the stated range.
By their numbers in this assay, from the lowest: compounds 3, 1 and 2 (each within the scatter of the next, the first and the last beyond it).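

In this assay, for the compounds shown here, the 2,6-dimethylphenyl group on the amide-type nitrogen gives the first step at this position that lies beyond the scatter (a number 12.7 percentage points lower from compound 2 to compound 3 (beyond the scatter)), while the comparison with the 4-methylphenyl group stays within it (a number 5.4 percentage points lower from compound 1 to compound 3 (within the scatter)). The three groups therefore do not separate cleanly: 2,6-dimethylphenyl can be told apart from 4-(trifluoromethyl)phenyl, but neither of these can be told apart from 4-methylphenyl. No measurement shown here gives a reason for these numbers.

The compounds shown leave open how a terminal phenyl carrying a methoxy group, an amine or a carboxylic acid would read at this position, and whether a saturated cyclohexyl ring could stand in for the phenyl. With a single concentration per compound, they also leave the potency of all three undefined.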